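The source may hold more compounds than are shown below. What is called first, only, known or untested is meant among the compounds shown, and "the series" means these compounds.

Measured so far:
compound 1 `O=C(Cc1cccnc1)c1cc2ccccc2[nH]1`: 13%
compound 3 `COc1ccc2[nH]c(C(=O)Cc3cccnc3)cc2c1O`: 11%
compound 2 `OC(Cc1cccnc1)c1cc2ccccc2[nH]1`: "not active" (no number reported), no number

In an in vitro assay on P815B cells for inhibition of Indoleamine 2,3-dioxygenase 1 (Mus musculus), tested at 20 uM (a lower number here means less inhibition, a higher number more inhibition at the concentration tested (going by the name of the read-out)), compound 1 gives 13% and compound 3 gives 11%; the two values lie within the scatter of each other. Compound 2 is reported as "not active" (no number reported) in this assay and carries no number, so it cannot be placed on the numbers at all. Compound 4 `c1cncc(CCc2cc3ccccc3[nH]2)c1` differs from compound 2 by hydrogen in place of hydroxy on a saturated chain carbon bound to an aromatic carbon and a saturated chain carbon. Within the data shown here, no step between measured compounds covers this change. With compound 2 lacking a number and the numbered compounds both showing only weak inhibition, the expected result in this assay is a small value, with no direction claimed beyond the scatter. Compound 4 is expected to give 10% in this assay, within a range from 0% to 25%.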

Compound 4, a percentage reported as inhibition, at one concentration (the size of the read-out at that concentration, not a potency): "not active" (no number reported)
Compound 4: no number reported; the estimate stays without a comparison.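

With compound 2 at "not active" (no number reported) and compound 4 at "not active" (no number reported) in this assay no step can be read between them. As far as these compounds go, whether exchanging hydroxy for hydrogen on this saturated chain carbon alters inhibition remains open. No evidence bears on this result.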